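Positive modulator series: piperazine aryl group replaced by phenyl

The source may report more compounds than this note shows. Statements on the series, on what has been measured and on what is new or still open speak of the compounds shown alone.

Three compounds have numbers in a functional assay on CHO cells with metabotropic glutamate receptor 2 (Homo sapiens) as the target, read by GTPgammaS binding; a lower number here means a smaller maximal response, a higher number a larger maximal response. Compound 1 `CCCCn1ccc(N2CCN(c3nc(C)cc(C)n3)CC2)c(C#N)c1=O` gives 235%. Compound 2 `CCCc1cnc2c(C#N)c(N3CCN(c4ncccn4)CC3)ccn12` gives 248%, the highest of the three, with compound 1 next and compound 3 `CCc1cnc2c(C#N)c(N3CCN(c4ncccn4)CC3)ccn12` furthest at 214%. Among the compounds with values here, the one single-point step is a number 34 percentage points lower from compound 2 to compound 3 (beyond the scatter), a change on the chain, not on the aryl group.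

Compound 4 `CCCc1cnc2c(C#N)c(N3CCN(c4ccccc4)CC3)ccn12` carries phenyl in place of pyrimidin-2-yl on an amine nitrogen in a ring. Within the data shown here, no measured step touches that position; compound 1 differs from compound 2 in more than one place and shows only that its number is lower. The step to compound 4 is therefore expected to be a number 28 percentage points lower from compound 2 to compound 4 (beyond the scatter), with wide uncertainty. Compound 4 is estimated at 220%, between 170% and 265%.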

Compound 4, largest response reached (Emax), in percent of the reference or control that the assay uses: 241%
Beside the measured number, compound 4's estimate is 21 percentage points below it; the range from low to high includes it.
By their numbers in this assay, from the lowest: compound 3; then compounds 1, 4 and 2 (each within the scatter of the next, the first and the last beyond it).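

In this assay, the change from pyrimidin-2-yl to phenyl on the amine nitrogen gives a number 7 percentage points lower from compound 2 to compound 4 (within the scatter). For this pair, the number therefore does not depend on the aromatic ring nitrogens or on the hydrogen-bond acceptors counted for pyrimidin-2-yl, which phenyl lacks. No evidence on the origin of this result is available.

The compounds shown leave open how a substituted phenyl, a benzyl or a cyclohexyl group would read at this position. They also leave open whether phenyl gives the same result with the ethyl chain of compound 3 or on the core of compound 1.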